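This account rests on a few compounds, and the source may have more. Where it says the series, first, only, none or still open, it means among the compounds named here.

Of the compounds shown here, two that share one core have so far been tested in an assay on isolated protein for inhibition of 2-Hydroxyacid oxidase 2 (Homo sapiens), tested at 10 uM; on this read-out lower numbers stand for a weaker effect and higher numbers for a stronger effect at the one concentration tested. Compound 1 `Cc1n[nH]c(C(=O)O)c1Cc1cccc(-c2ccc(OC(F)(F)F)cc2)c1` gives 34% there, the higher of the two numbers in hand. Compound 2 `Cc1n[nH]c(C(N)=O)c1Cc1cccc(-c2ccc(F)cc2)c1` gives 14% in this assay, a gap that lies beyond the usual scatter of repeated measurements. These two compounds differ in more than one place, so the gap between them cannot be tied to any single change; only their two values are known.

Compound 3 `Cc1n[nH]c(C(=O)O)c1Cc1cccc(-c2ccc(C(F)(F)F)cc2)c1` has not yet been measured in this assay. It differs from compound 1 in one place, on the ring that sits farthest from the core: trifluoromethyl in place of trifluoromethoxy on an aromatic carbon. Within the data shown here, no measured pair in hand isolates a change of this kind, so there is nothing to show how large its effect might be. On that basis the step from compound 1 to compound 3 is expected to be small, a number 4 percentage points lower from compound 1 to compound 3 (within the scatter), lying within the usual scatter rather than beyond it. Compound 3 is therefore estimated to give about 30% in this assay, with a likely range from 15% to 48%.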

Compound 3, a percentage reported as inhibition, at one concentration (the size of the read-out at that concentration, not a potency): 30%
For compound 3 middle estimate and measured number coincide at the digits printed, and the stated range covers the measured number.
By their numbers in this assay, from the lowest: compound 2; then compounds 3 and 1 (each within the scatter of the next).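

Among these compounds, the change to trifluoromethyl in place of trifluoromethoxy on an aromatic carbon, para to a large group, is the first single change that can be read in this assay and it amounts to a number 4 percentage points lower from compound 1 to compound 3 (within the scatter) with everything else in the molecule held the same. For this pair, then, removing the oxygen atom that links the trifluoromethoxy group to the ring leaves a difference that this read-out cannot distinguish from repeat-to-repeat variation, so the two groups cannot be told apart here. Nothing at hand explains why the two groups read alike.

As far as these compounds go, both groups compared at this place carry three fluorines, so it remains open how a group without fluorine, such as a methoxy group or an amine, would read at the same position. From the compounds shown here alone, the carboxylic acid on the core also remains untested as a single change, since compound 2 carries an amide there but differs from compound 1 and compound 3 in more than one place.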